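Thiophene for furan on the saturated ring carbon

The compounds below may be only part of what the source reports. "The series", "measured", "known", "first", "only" and "open" are said of these compounds alone.

Compound 1 `CC1=C(C(=O)OCC(C)C)C(c2ccco2)NC(=S)N1` and compound 2 `CC1=C(C(=O)OCC(C)C)C(c2ccoc2)NC(=S)N1` share one core and differ only in the furan attachment. In an assay on membranes from HeLa cells for displacement of a labelled ligand from adenosine receptor A3 (Homo sapiens), read by scintillation counting, with a stated time of 180 min, tested at 1 uM (a higher number here means more inhibition at the concentration tested (going by the name of the read-out), a lower number less inhibition), compound 1 gives 10%. In this assay compound 2 gives 1%. The step of a number 9 percentage points lower from compound 1 to compound 2 (within the scatter) is the only measured one in the series; it lies within the scatter, so compound 2 stands on the lower of the two numbers without any real separation from compound 1.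

Compound 3 `CC1=C(C(=O)OCC(C)C)C(c2ccsc2)NC(=S)N1` follows from compound 2 by the change (thiophen-3-yl in place of furan-3-yl on a saturated ring carbon). Among the compounds with values here, no measured step exchanges furan for thiophene; the one step available, a number 9 percentage points lower from compound 1 to compound 2 (within the scatter), concerns a different change and shows no shift beyond the scatter. The expectation is therefore a step of a number 5 percentage points higher from compound 2 to compound 3 (within the scatter), with no clear direction beyond the scatter. Compound 3 is estimated to give 6%, within a range from -10% to 25%.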

Compound 3, a percentage reported as inhibition, at one concentration (the size of the read-out at that concentration, not a potency): 2%
The estimate for compound 3 lay 4 percentage points above the measured number; the range from low to high includes it.
By their numbers in this assay, from the lowest: compounds 2, 3 and 1 (each within the scatter of the next).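

In this assay, thiophen-3-yl in place of furan-3-yl on the saturated ring carbon gives a number 1 percentage points higher from compound 2 to compound 3 (within the scatter) and so adds sulfur for oxygen in this ring to the changes that stay within the scatter. The step of a number 8 percentage points lower from compound 1 to compound 3 (within the scatter) shows the same when the attachment and the hetero atom change together, so the three five-membered aromatic rings at this position are not separated from one another at the concentration tested. No measurement on hand offers an explanation for this result.

Open, going by these compounds, is whether thiophen-2-yl would fall in with these three, and whether a phenyl ring or a carboxylic acid on this carbon would lift the number clear of the scatter. Also open, on these data alone, is what a longer chain in the group of 7 heavy atoms would do in this assay.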